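Sulfonyl aryl swaps on a shared core: exposure notes

The source may report more compounds than this note shows. Statements on the series, on what has been measured and on what is new or still open speak of the compounds shown alone.

The series shares one core, carried in compound 1 `CNCc1cn(S(=O)(=O)c2ccco2)c(-c2cccnc2F)c1F`, compound 2 `CNCc1cn(S(=O)(=O)c2ccccn2)c(-c2cccnc2F)c1F`, compound 3 `CNCc1cn(S(=O)(=O)c2cccc(F)n2)c(-c2cccnc2F)c1F` and the still unmeasured compound 4 `CNCc1cn(S(=O)(=O)c2cccnc2Cl)c(-c2cccnc2F)c1F`. In an ADME assay on the whole organism (plasma, Rattus norvegicus, strain Sprague-Dawley) for pharmacokinetics, read by LC-MS, using cassette dosing, at a dose of 0.2 mg/kg by the intravenous route (on this read-out higher numbers stand for higher exposure at the dose given and lower numbers for lower exposure), compound 1 gives 26 ng.h/mL, which stands as the lower of the two numbers in hand, a gap that the scatter covers. In this assay compound 2 gives 33 ng.h/mL. In this assay compound 3 gives "not determined" (no result reported), so no number stands for it. For the measured compounds named here, the only measured step with a single change, a 1.3-fold higher number from compound 1 to compound 2 (0.10 log units; within the scatter), trades one aromatic group on the sulfonyl sulfur for another and stays within the scatter, so these two numbers show no ordering.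

Compound 4 differs from compound 1 by 2-chloropyridin-3-yl in place of furan-2-yl on a sulfonyl sulfur. Going by the values given here, this is the same kind of change at the same place as the one step in hand, and that step was within the scatter; no measured pair touches the 2-chloropyridin-3-yl group itself, so nothing in hand speaks for a shift beyond the scatter. The expectation for compound 4 in this assay is therefore a step of about a 1.2-fold higher number from compound 1 to compound 4 (0.06 log units; within the scatter), in no firm direction. Compound 4 is estimated at 30 ng.h/mL, with a deliberately wide range from 10 ng.h/mL to 90 ng.h/mL.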

Compound 4, area under the concentration-time curve: 33 ng.h/mL
Compound 4: middle estimate off by 1.1-fold (0.04 log units), on the low side, and the stated range covers the measured number.
By their numbers in this assay, from the lowest: compounds 1, 2 and 4 (each within the scatter of the next).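

In this assay, replacing the five-membered aromatic furan-2-yl on the sulfonyl sulfur with the six-membered, chlorine-bearing 2-chloropyridin-3-yl gives a 1.3-fold higher number from compound 1 to compound 4 (0.10 log units; within the scatter), so this larger change of ring and substituent does not separate the two compounds on exposure. Against pyridin-2-yl, the other six-membered aromatic group at this place, the same group gives no change at the digits printed from compound 2 to compound 4 (within the scatter), which adds a second comparison and shows that chlorine on the pyridine ring, together with a different point of attachment, leaves the reading within the scatter. Compounds 1, 2 and 4 therefore form a set of three aromatic groups on the sulfonyl sulfur with no ordering among them, and no supporting measurement is available to explain this result.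

On these data alone, all three groups with a number are aromatic rings, so it remains open whether the same reading would hold with a saturated group on the sulfonyl sulfur, such as a cyclopropyl ring or a short alkyl chain. The methylaminomethyl side chain and the 2-fluoropyridine part of the core are also constant throughout, leaving open how a change there, such as a carboxylic acid in place of the amine, would read in this assay.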